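Trimming Chlorines on a Sulfonamide Aryl Group

The source may hold more compounds than are shown below. What is called first, only, known or untested is meant among the compounds shown, and "the series" means these compounds.

Measured so far:
compound 1, `O=S(=O)(NCCCCCCNCc1ccc(Br)cc1)c1cc(Cl)cc(Cl)c1`: 12000 nM
compound 2, `O=S(=O)(NCCCCCCNCc1ccc(Br)cc1)c1c(Cl)cc(C(F)(F)F)cc1Cl`: 5670 nM

Of the compounds shown here, two have been tested in a functional assay on MIA PaCa-2 cells (Homo sapiens) for inhibition, read by MTT assay, with a stated time of 72 h; a lower number here means a stronger inhibitor of growth, a higher number a weaker inhibitor of growth. Compound 1 gives 12000 nM in this assay, the higher of the two numbers. Compound 2 sits lower, and the gap between them is beyond the usual scatter of this kind of measurement, so compound 1 is the weaker growth inhibitor of the pair.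

Compound 3, `O=S(=O)(NCCCCCCNCc1ccc(Br)cc1)c1ccc(Cl)cc1`, has not yet been measured in this assay. Relative to compound 1 it carries 4-chlorophenyl in place of 3,5-dichlorophenyl on a sulfonyl sulfur. Among the measured compounds shown here, no measured pair shows this exact change, so its effect is open. Given that the more heavily substituted compound 2 sits lower than compound 1, a move to the less substituted 4-chlorophenyl is expected to leave the number where it is or push it somewhat higher, with the expected step being a 1.3-fold higher number from compound 1 to compound 3 (0.12 log units; within the scatter). Compound 3 is therefore estimated at 16000 nM, with a range from 7000 nM to 36000 nM.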

Compound 3, concentration for 50% growth inhibition: 5900 nM
Compound 3: the middle estimate sits 2.7-fold (0.43 log units) above what was measured; the measured number lies below the stated range.
By their numbers in this assay, from the lowest: compounds 2 and 3 (each within the scatter of the next); then compound 1.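

In this assay, 4-chlorophenyl in place of 3,5-dichlorophenyl on a sulfonyl sulfur gives a 2.0-fold lower number from compound 1 to compound 3 (0.31 log units; beyond the scatter) and so shows that this aryl group can lose a chlorine without a rise in the number. Compound 2 and compound 3 lie within the scatter of each other, so the group with one chlorine and the more heavily substituted group in compound 2 cannot be told apart here, and more substitution is not needed for the lower number. Nothing measured alongside these numbers accounts for this step.

This step changes the number of chlorines and their places together, and the compounds shown do not separate those two changes. Also open, on these data alone, is how a plain phenyl or a 4-methoxyphenyl would behave on the same sulfonyl sulfur.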